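The source may hold more compounds than are shown below. What is called first, only, known or untested is meant among the compounds shown, and "the series" means these compounds.

Two measured compounds share one core and differ only in the group attached to the carbon with a double bond to nitrogen. In a functional assay on HeLa cells (Homo sapiens) for inhibition, read by CCK-8 assay, with a stated time of 48 h (a lower number here means a stronger inhibitor, a higher number a weaker inhibitor), compound 1 `Cc1ccc(C2=NN(C3=NC(c4ccccc4)CS3)C(c3ccc4ccccc4c3)C2)cc1` gives 2460 nM. Compound 2 `c1ccc(C2=NN(C3=NC(c4ccccc4)CS3)C(c3ccc4ccccc4c3)C2)cc1` gives 3860 nM in this assay, the highest of the two numbers shown, with compound 1 nearest to it. The step of a 1.6-fold higher number from compound 1 to compound 2 (0.20 log units; within the scatter) is the only one recorded, and it bears directly on the next change. Compound 3 `Cc1ccc(C2=NN(C3=NC(c4ccccc4)CS3)C(c3ccc4ccccc4c3)C2)cc1C` differs from compound 2 by 3,4-dimethylphenyl in place of phenyl on a carbon with a double bond to nitrogen. Within the data shown here, since the single step from compound 1 to compound 2 stayed within the scatter, a change that adds two methyl groups on the same ring gives no firm ground for expecting more than a small shift. The expected step of a 1.9-fold lower number from compound 2 to compound 3 (0.29 log units; within the scatter) therefore points slightly downward, and compound 3 is estimated at 2000 nM in this assay, within the range 800 nM to 5000 nM.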

Compound 3, half-maximal inhibitory concentration: 950 nM
Beside the measured number, compound 3's estimate is 2.1-fold (0.32 log units) above it; low and high end bracket the measured number.
By their numbers in this assay, from the lowest: compound 3; then compounds 1 and 2 (each within the scatter of the next).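

In this assay, the ring on the carbon with a double bond to nitrogen now gives a change that lies beyond the scatter, with 3,4-dimethylphenyl in place of phenyl giving a 4.1-fold lower number from compound 2 to compound 3 (0.61 log units; beyond the scatter) as the step. One added methyl on that ring also gives a readable change in the step of a 2.6-fold lower number from compound 1 to compound 3 (0.41 log units; beyond the scatter) while the earlier step of a 1.6-fold higher number from compound 1 to compound 2 (0.20 log units; within the scatter) stayed within the scatter, so among these three compounds only the step to compound 3 separates clearly, and this position is shown to be able to move the number. No measurement shown gives a reason for this result.

The compounds shown leave open how a methoxy group, a chlorine atom or an amine on this ring would compare with 3,4-dimethylphenyl. They also leave open whether the same change would hold with another group in place of the naphthalen-2-yl group.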